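The source may hold more compounds than are shown below. What is called first, only, known or untested is meant among the compounds shown, and "the series" means these compounds.

Measured so far in a functional assay on DLD-1 cells (Homo sapiens) for antiproliferative activity, read by CellTiter-Glo, with a stated time of 72 h; on this read-out higher numbers stand for weaker inhibition and lower numbers for stronger inhibition:

Compound 1 `Cc1cc(C)c(S(=O)(=O)N2CCC(N3CCC(CCO)CC3)CC2)c(C)c1` gives 19 nM in this assay.
Compound 2 `Cc1cc(C)c(S(=O)(=O)N2CCC(c3ccccc3)CC2)c(C)c1` gives only a limit of the assay, > 5000 nM, in this assay.
Compound 3 `Cc1cc(C)c(S(=O)(=O)N2CCC(N3CCCCC3)CC2)c(C)c1` gives 2200 nM in this assay.

Compound 3 stands as the highest of the two numbers that are actual numbers; its nearest neighbour is compound 1, and the step of a 120-fold higher number from compound 1 to compound 3 (2.06 log units; beyond the scatter) shows how far apart they lie. Within the data shown here, the one remaining value, that of compound 2, is a limit (the limit of > 5000 nM in this assay, at which 1 of the 3 values shown sits).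

Compound 4 `Cc1cc(C)c(S(=O)(=O)N2CCC(N3CCC(C)OC3)CC2)c(C)c1` has not yet been measured. It differs from compound 3 in one place: a group of 7 heavy atoms (5 carbon, 1 nitrogen, 1 oxygen; one six-membered non-aromatic ring with 2 hetero atoms) in place of a group of 6 heavy atoms (5 carbon, 1 nitrogen; one six-membered non-aromatic ring with 1 hetero atom), on a saturated ring carbon. The ring that enters keeps the nitrogen through which it is attached and brings one oxygen into the ring.

Among the measured compounds shown here, two measured steps bear on this. The step of a 120-fold higher number from compound 1 to compound 3 (2.06 log units; beyond the scatter) shows that adding a 2-hydroxyethyl tail, with its oxygen, to the piperidin-1-yl ring made a large difference; removing it lost most of the activity. The step of an at least 2.2-fold lower number from compound 2 to compound 3 (0.35 log units; beyond the scatter) shows that the ring nitrogen itself is worth at least a modest amount. Compound 4 keeps that nitrogen and adds an oxygen, but as an acceptor inside the ring rather than as a hydroxyl at the end of a chain, so the gain seen in compound 1 is not expected to carry over in full.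

The expected outcome for compound 4 in this assay is a step of a 2.2-fold lower number from compound 3 to compound 4 (0.34 log units; beyond the scatter). The estimate for compound 4 is 1000 nM, with a likely range from 200 nM to 5000 nM.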

Compound 4, half-maximal inhibitory concentration: 92 nM
Beside the measured number, compound 4's estimate is 11-fold (1.04 log units) above it, outside the stated range (below it).
By their numbers in this assay, from the lowest: compound 1; then compound 4; then compound 3. At a limit, above all of these: compound 2.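

In this assay, among these compounds, the earlier compounds suggested that strong inhibition needed the 2-hydroxyethyl tail, yet a ring with an oxygen inside it and no such tail changes the picture, giving a 24-fold lower number from compound 3 to compound 4 (1.38 log units; beyond the scatter) while leaving only a 4.8-fold higher number from compound 1 to compound 4 (0.69 log units; beyond the scatter). A hydroxyl at the end of a chain is therefore not required for much of the gain at this saturated ring carbon, although compound 1 keeps the lower number, and the change from the phenyl group is also large, with an at least 54-fold lower number from compound 2 to compound 4 (1.73 log units; beyond the scatter). That last step rests on compound 2, whose value is not a number but a limit: the limit of > 5000 nM in this assay, at which 1 of the 4 values shown sits.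

The compounds shown do not separate the effect of the ring oxygen from that of the methyl group on the same ring. A morpholin-4-yl group, or a piperidin-1-yl ring carrying only a methyl group, would help to tell the two apart.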